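A few compounds are considered here, and "the series" means these few. Any claim that something is new, unique, unknown or untested is made for them only; others in the source may bear on it.

Compound 1 `C[C@@H](NC1CCN(CCCc2c[nH]c3ccc(-n4cnnc4)cc23)CC1)c1ccccc1` gives 0.4 nM in an assay on CHO cells for displacement of a labelled ligand from 5-hydroxytryptamine receptor 1D (Homo sapiens); on this read-out lower numbers stand for stronger inhibition and higher numbers for weaker inhibition.
Compound 2 `CN(Cc1ccco1)C1CCN(CCCc2c[nH]c3ccc(-n4cnnc4)cc23)CC1` gives 9.3 nM in this assay.
Compound 3 `C[C@@H](NCC1CCN(CCCc2c[nH]c3ccc(-n4cnnc4)cc23)CC1)c1ccccc1` gives 1.4 nM in this assay.

Compound 3 stands second of the three numbers, with a stronger compound 1 on one side and a weaker compound 2 on the other; the steps that reach it are a 3.5-fold higher number from compound 1 to compound 3 (0.54 log units; beyond the scatter) and a 6.6-fold lower number from compound 2 to compound 3 (0.82 log units; beyond the scatter).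

Compound 4 `c1ccc2c(c1)CCC2NCC1CCN(CCCc2c[nH]c3ccc(-n4cnnc4)cc23)CC1` differs from compound 3 in one place: 2,3-dihydro-1H-inden-1-yl in place of 1-phenylethyl on an amine nitrogen. Among the measured compounds shown here, no measured step alters this group, so the evidence is indirect. For the measured compounds named here, the only exchange of the group on the amine nitrogen is a 23-fold higher number from compound 1 to compound 2 (1.37 log units; beyond the scatter), a much broader swap; here the 1-phenylethyl and 2,3-dihydro-1H-inden-1-yl groups share one six-membered aromatic ring of carbon only, so in this assay a step within the scatter, or a small one toward a higher number, is expected. Compound 4 is therefore estimated at 2 nM, between 0.7 nM and 6 nM, which means an expected 1.4-fold higher number from compound 3 to compound 4 (0.15 log units; within the scatter).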

Compound 4, half-maximal inhibitory concentration: 1.1 nM
Compound 4: the middle estimate sits 1.8-fold (0.26 log units) above what was measured; the measured number falls inside the stated range.
By their numbers in this assay, from the lowest: compound 1; then compounds 4 and 3 (each within the scatter of the next); then compound 2.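

In this assay, the 2,3-dihydro-1H-inden-1-yl group, with its extra five-membered ring and no defined stereocentre, is accepted on this amine nitrogen as well as 1-phenylethyl: a 1.3-fold lower number from compound 3 to compound 4 (0.10 log units; within the scatter). The wider swaps, an 8.5-fold lower number from compound 2 to compound 4 (0.93 log units; beyond the scatter) and a 2.8-fold higher number from compound 1 to compound 4 (0.44 log units; beyond the scatter), leave compound 4 close to where compound 3 already stood. No independent evidence here explains this tolerance.

Still open, as far as these compounds go, is whether (2,3-dihydro-1H-inden-1-yl)amino placed directly on the saturated ring carbon would match compound 1, and how a 1,2,3,4-tetrahydronaphthalen-1-yl group on the amine nitrogen would fare.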